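A few compounds are considered here, and "the series" means these few. Any claim that something is new, unique, unknown or untested is made for them only; others in the source may bear on it.

Of the compounds shown here, three sharing one core have so far been tested in an assay for inhibition of NAD-dependent protein deacylase sirtuin-6 (Homo sapiens), read by HPLC, with stated times of 15 min and 1 h, tested at 333 uM; a higher number here means more inhibition at the concentration tested (going by the name of the read-out), a lower number less inhibition. Compound 1 `CCCCCCCCNC(=O)CCCSC[C@H](NC(=O)OCc1ccccc1)C(=O)Nc1ccccc1` is reported there as "not active" (no number reported), with no number attached. Compound 2 `CCCCNC(=O)CCCSC[C@H](NC(=O)OCc1ccccc1)C(=O)Nc1ccccc1` gives 26%. Compound 3 `O=C(O)CCCNC(=O)CCCSC[C@H](NC(=O)OCc1ccccc1)C(=O)Nc1ccccc1` gives 35%. The difference between these last two, a number 9 percentage points higher from compound 2 to compound 3 (within the scatter), means their numbers cannot be told apart, and compound 1 offers no number to set against them, so compound 3 stands on level ground with compound 2 rather than apart from it.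

Compound 4 `O=C(O)CCNC(=O)CCCSC[C@H](NC(=O)OCc1ccccc1)C(=O)Nc1ccccc1` differs from compound 3 in one place: carboxy in place of carboxymethyl on a saturated chain carbon, two bonds along the chain from an amide-type nitrogen. Among the measured compounds shown here, the only measured step touching this end of the molecule is the one from compound 2 to compound 3, and it lay within the scatter. For the measured compounds named here, no measured pair shows this particular exchange, carboxy in place of carboxymethyl, so there is nothing pointing to a shift in either direction. The change is therefore expected to produce a step of about a number 3 percentage points lower from compound 3 to compound 4 (within the scatter), nothing beyond the scatter. Compound 4 is expected to give roughly 32%, with a likely range from 18% to 46%.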

Compound 4, a percentage reported as inhibition, at one concentration (the size of the read-out at that concentration, not a potency): 43%
Compound 4: middle estimate off by 11 percentage points, on the low side, within the range that was stated.
By their numbers in this assay, from the lowest: compounds 2, 3 and 4 (each within the scatter of the next, the first and the last beyond it).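

In this assay, carboxy in place of carboxymethyl at this place gives a number 8 percentage points higher from compound 3 to compound 4 (within the scatter), so this change of chain length alone cannot be told apart from no change. Among the compounds shown here, the clearer result is carboxy in place of ethyl, which gives a number 17 percentage points higher from compound 2 to compound 4 (beyond the scatter), the first step in this set to pass beyond the scatter and the first sign that a carboxy group at this place goes with more inhibition at the concentration tested than the plain chain end of compound 2. Compound 3 goes against any simple reading of a carboxy group as enough by itself, since a number 9 percentage points higher from compound 2 to compound 3 (within the scatter) stays within the scatter.

No measurement shown explains this step. As far as these compounds go, it remains open whether an amine or a methyl ester at this chain end would match the carboxy group, and whether compound 4's chain could be shortened further.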